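Swapping an Acetyl for a Benzoyl on a Small Lactone

The source may hold more compounds than are shown below. What is called first, only, known or untested is meant among the compounds shown, and "the series" means these compounds.

Compound 1 `CC(=O)O[C@@H]1OC(=O)[C@@](C)(C(C)=O)[C@@H]1C` is the starting point. In a functional assay on DA-3 cells for cytotoxicity against DA-3 cell line (Mus musculus), read by MTT assay (a lower number here means a stronger inhibitor, a higher number a weaker inhibitor), compound 1 gives 9000 nM, the lowest of the two numbers shown here. Compound 2 `CC(=O)O[C@@H]1OC(=O)[C@@](Cc2ccccc2)(C(C)=O)[C@@H]1C` gives 44000 nM in this assay. Compound 3 `CC(=O)O[C@@H]1OC(=O)[C@@](OC(C)=O)(C(C)=O)[C@@H]1C` gives > 50000 nM in this assay, which is a limit of the assay rather than a number (the limit of > 50000 nM in this assay, at which 1 of the 3 values shown sits). Compound 4 `CC(=O)O[C@@H]1OC(=O)[C@@](C)(C(=O)c2ccccc2)[C@@H]1C` has not yet been measured; compared with compound 1 the change is phenyl in place of methyl on a carbonyl carbon. Within the data shown here, two measured steps bear on it: a 4.9-fold higher number from compound 1 to compound 2 (0.69 log units; beyond the scatter) and an at least 5.5-fold higher number from compound 1 to compound 3 (0.74 log units; beyond the scatter), each making the compound weaker. A similar modest weakening is therefore expected, a 2.8-fold higher number from compound 1 to compound 4 (0.44 log units; beyond the scatter). Compound 4 is accordingly expected to give about 25000 nM, within the range 8000 nM to 70000 nM.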

Compound 4, half-maximal inhibitory concentration: 15000 nM
Estimate against measurement, compound 4: 1.7-fold (0.22 log units) above; the range from low to high includes it.
By their numbers in this assay, from the lowest: compounds 1 and 4 (each within the scatter of the next); then compound 2. At a limit, above all of these: compound 3.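

In this assay putting phenyl in place of methyl on the carbonyl carbon gives a 1.7-fold higher number from compound 1 to compound 4 (0.22 log units; within the scatter) and so no real change. The changes on the saturated ring carbon in compound 2 and compound 3 both went beyond the scatter, so this carbonyl carbon is the first place shown to accept a six-membered aromatic ring without a readable loss. No measured property among the data shown explains this result.

On these data alone, whether an amine, a carboxylic acid or a longer chain on this carbonyl carbon would also leave the number unchanged, or would lower it, remains open.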